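Switching the Aryl Sulfonamide: Compound 3 to Compound 4

The compounds below may be only part of what the source reports. "The series", "measured", "known", "first", "only" and "open" are said of these compounds alone.

In a functional assay on a cell-free system (plasma) for inhibition of thromboxane A2 receptor (Homo sapiens), read by turbidimetry (on this read-out lower numbers stand for stronger inhibition and higher numbers for weaker inhibition), compound 3 `O=C(O)CC/C=C\CC1=CCC[C@@H]1NS(=O)(=O)c1ccc(Cl)cc1` gives 1900 nM. Compound 1 `O=C(O)CC/C=C\CC1=CCC[C@@H]1NS(=O)(=O)c1ccc(Cl)c(Cl)c1` gives 1900 nM, and compound 2 `O=C(O)COCCCCC1=CCC[C@@H]1NS(=O)(=O)c1ccc(F)cc1F` gives 1800 nM; compound 3 stands level with compound 1 at the digits shown, and its gap to compound 2 lies within the scatter. The step of no change at the digits printed from compound 1 to compound 3 (within the scatter) shows that removing one chloro from the aryl ring left the read-out unchanged. Compound 4 `O=C(O)CC/C=C\CC1=CCC[C@@H]1NS(=O)(=O)c1ccc(F)cc1F` carries 2,4-difluorophenyl in place of 4-chlorophenyl on a sulfonyl sulfur. The same 2,4-difluorophenyl sits in compound 2, whose value differs from that of compound 3 only within the scatter, although its chain is different. Compound 4 is therefore expected to show no change at the digits printed from compound 3 to compound 4 (within the scatter). Compound 4 is estimated at 1900 nM, with a range from 900 nM to 4000 nM.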

Compound 4, half-maximal inhibitory concentration: 20000 nM
For compound 4 the middle estimate is 11-fold (1.02 log units) below the measured one; the measured number lies above the stated range.
By their numbers in this assay, from the lowest: compounds 2, 1 and 3 (each within the scatter of the next); then compound 4.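

On a sulfonyl sulfur, the aryl group proved not to be freely exchangeable on this chain: 2,4-difluorophenyl in place of 4-chlorophenyl gave an 11-fold higher number from compound 3 to compound 4 (1.02 log units; beyond the scatter), and in place of 3,4-dichlorophenyl it gave an 11-fold higher number from compound 1 to compound 4 (1.02 log units; beyond the scatter), although compound 1 and compound 3 stand level. The chain also matters, as the earlier compounds had not shown: with 2,4-difluorophenyl held fixed, 4-carboxybut-1-en-1-yl in place of 3-(carboxymethoxy)propyl gave an 11-fold higher number from compound 2 to compound 4 (1.05 log units; beyond the scatter). Nothing available gives a reason for these steps. Going by these compounds, whether a bromo or a nitrile on the aryl ring would stay level with compound 3 remains open.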